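Replacing the Aryl Group of Compound 3

The source may report more compounds than this note shows. Statements on the series, on what has been measured and on what is new or still open speak of the compounds shown alone.

Of the compounds shown here, three have so far been read in an ADME assay on HEK293 cells (Homo sapiens) for cytotoxicity, read by MTT assay, with a stated time of 24 h; a higher number here means a weaker inhibitor, a lower number a stronger inhibitor. Compound 1 (`CN1CCN(CCCNc2nc3cc([N+](=O)[O-])ccc3nc2NCc2ccc(C(F)(F)F)cc2)CC1`) gives 9.53 ug/mL, compound 2 (`CN1CCN(c2nc3cc([N+](=O)[O-])ccc3nc2NCc2ccc(C(F)(F)F)cc2)CC1`) gives 6.99 ug/mL, and compound 3 (`CN(C)CCCNc1nc2cc([N+](=O)[O-])ccc2nc1NCc1ccc(F)cc1`) gives 4.28 ug/mL. The number for compound 3 thus lies within the usual scatter of the number for compound 2, and beyond the scatter below that of compound 1.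

Compound 4 (`CN(C)CCCNc1nc2cc([N+](=O)[O-])ccc2nc1NCc1cccc(C(F)(F)F)c1`) has not yet been measured. It differs from compound 3 in one place: 3-(trifluoromethyl)phenyl in place of 4-fluorophenyl on a saturated chain carbon bound to a nitrogen on an aromatic ring. In words, 3-(trifluoromethyl)phenyl stands in place of 4-fluorophenyl on a saturated chain carbon bound to a nitrogen on an aromatic ring.

Within the data shown here, the only measured step is a 1.4-fold lower number from compound 1 to compound 2 (0.13 log units; within the scatter). Among the measured compounds shown here, it concerns a different group, so it bears on this change only indirectly, and no measured step isolates the swap itself. Compounds 1 and 2 do carry a trifluoromethyl group, but they also differ from compound 3 elsewhere, so their higher-lying numbers offer only a weak hint of direction. The expected result is therefore a small move at most, with no shift beyond the scatter: the estimated step is a 1.3-fold higher number from compound 3 to compound 4 (0.11 log units; within the scatter). Compound 4 is expected at 5.5 ug/mL, within an estimated range of 2.6 ug/mL to 11.5 ug/mL in this assay.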

Compound 4, half-maximal inhibitory concentration: 7.99 ug/mL
Compound 4: middle estimate off by 1.5-fold (0.16 log units), on the low side; measured number inside the range.
By their numbers in this assay, from the lowest: compounds 3, 2, 4 and 1 (each within the scatter of the next, the first and the last beyond it).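

At the place on a saturated chain carbon bound to a nitrogen on an aromatic ring, the swap of 4-fluorophenyl for 3-(trifluoromethyl)phenyl can now be read on its own in this assay, and it gives a 1.9-fold higher number from compound 3 to compound 4 (0.27 log units; within the scatter). The step lies within the scatter, so compound 3 and compound 4 cannot be told apart in this assay, even though the entering group has 10 heavy atoms against 7 for the group that leaves and carries 3 fluorine atoms against 1. This place therefore accepts a group with more heavy atoms and more fluorine without a change that stands clear of the scatter, something the earlier step between compound 1 and compound 2, made at a different place, could not show, and nothing at hand offers a reason for the size of the new step.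

The swap alters both the fluorine-bearing group and where it sits on the phenyl ring, so the compounds shown do not separate these two changes. Going by these compounds, how a plain phenyl, a 3-fluorophenyl or a pyridine ring would read at this place, on the same core and dimethylamino chain, remains open.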